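Removing a Methoxy Group from Compound 3

The compounds below may be only part of what the source reports. "The series", "measured", "known", "first", "only" and "open" are said of these compounds alone.

Compound 1 `CC(=O)/C(=C\c1c(-c2ccccc2)[nH]c2ccccc12)S(=O)(=O)c1ccccc1` gives 1300 nM in a functional assay on NCI-H522 cells (Homo sapiens) for inhibition, read by sulforhodamine B assay, with a stated time of 48 h; on this read-out higher numbers stand for weaker inhibition of growth and lower numbers for stronger inhibition of growth. Compound 2 `O=C(/C(=C\c1c(-c2ccccc2)[nH]c2ccccc12)S(=O)(=O)c1ccccc1)c1ccccc1` gives 91800 nM. Compound 3 `COc1ccc2[nH]c(-c3ccccc3)c(/C=C(\C#N)S(=O)(=O)c3ccccc3)c2c1` gives 4000 nM.

Compound 3 stands second highest of these three numbers, nearer to compound 1 than to compound 2. Compound 4 `N#C/C(=C\c1c(-c2ccccc2)[nH]c2ccccc12)S(=O)(=O)c1ccccc1` differs from compound 3 by hydrogen in place of methoxy on an aromatic carbon. Going by the values given here, the only measured step, a 71-fold higher number from compound 1 to compound 2 (1.85 log units; beyond the scatter), concerns the carbonyl substituent and does not bear on the change at the aromatic ring, so no measured step speaks to this change. For compound 4 the expectation is therefore a step of a 1.1-fold lower number from compound 3 to compound 4 (0.06 log units; within the scatter), that is nothing beyond the scatter, and compound 4 is estimated at 3500 nM with a range from 1000 nM to 12000 nM.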

Compound 4, concentration for 50% growth inhibition: 4600 nM
For compound 4 the middle estimate is 1.3-fold (0.12 log units) below the measured one, within the range that was stated.
By their numbers in this assay, from the lowest: compound 1; then compounds 3 and 4 (each within the scatter of the next); then compound 2.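

At this aromatic carbon, hydrogen and methoxy cannot be told apart in this assay, with a 1.2-fold higher number from compound 3 to compound 4 (0.06 log units; within the scatter). Compound 4 also allows the group on the double-bonded chain carbon to be compared on the core without methoxy, giving a 3.5-fold higher number from compound 1 to compound 4 (0.55 log units; beyond the scatter) for cyano against acetyl and a 20-fold lower number from compound 2 to compound 4 (1.30 log units; beyond the scatter) for cyano against benzoyl. Nothing available explains these steps.

On these data alone, whether an amine or a carboxylic acid at this aromatic carbon would give a similar number remains open. So does whether swapping methoxy for hydrogen would have as little effect with acetyl or benzoyl in place of cyano.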